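Branching the sulfur-borne alkyl group of an acylguanidine

A few compounds are considered here, and "the series" means these few. Any claim that something is new, unique, unknown or untested is made for them only; others in the source may bear on it.

Measured compounds:
- compound 1, `CCCc1cc(C)c(C(=O)N=C(N)N)cc1S(C)(=O)=O`, gives 5.7 nM in a functional assay for inhibition of sodium/hydrogen exchanger (Oryctolagus cuniculus); a lower number here means a stronger inhibitor, a higher number a weaker inhibitor
- compound 2, `CCSc1cc(C)c(C(=O)N=C(N)N)cc1S(C)(=O)=O`, gives 5.9 nM in this assay

Compound 2 has the highest of the two numbers in this assay, but the gap between them is only a 1.0-fold higher number from compound 1 to compound 2 (0.01 log units; within the scatter), so the two compounds are indistinguishable here. Compound 3, `Cc1cc(SC(C)(C)C)c(S(C)(=O)=O)cc1C(=O)N=C(N)N`, keeps the shared core and changes only the sulfur substituent: tert-butyl in place of ethyl on a sulfur. Within the data shown here, no measured step shows an ethyl-to-tert-butyl exchange on that sulfur; the only step available is a 1.0-fold higher number from compound 1 to compound 2 (0.01 log units; within the scatter), which exchanged a whole propyl for an ethylsulfanyl without moving the number. Going by these compounds, that points to a position that tolerates change, but a tert-butyl on that sulfur is untested, so a modest weakening is expected while a flat result stays plausible. The estimated step of a 1.7-fold higher number from compound 2 to compound 3 (0.23 log units; within the scatter) is expected to be small. Compound 3 is therefore estimated at 10 nM, in the range 3 nM to 40 nM.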

Compound 3, half-maximal inhibitory concentration: 22 nM
Estimate against measurement, compound 3: 2.2-fold (0.34 log units) below; the range from low to high includes it.
By their numbers in this assay, from the lowest: compounds 1 and 2 (each within the scatter of the next); then compound 3.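

In this assay, the sulfur substituent proves less forgiving than the first two compounds suggested: tert-butyl in place of ethyl gives a 3.7-fold higher number from compound 2 to compound 3 (0.57 log units; beyond the scatter) and so moves the result beyond the scatter, though only modestly. The comparison with the propyl compound points the same way, with a 3.9-fold higher number from compound 1 to compound 3 (0.59 log units; beyond the scatter) for (tert-butyl)sulfanyl in place of propyl, so this position does not tolerate every change equally, even though propyl and ethylsulfanyl could not be told apart. No measured evidence here explains the weakening seen with compound 3.

Going by these compounds, what stays open is whether the weakening already appears with a single branch, as an isopropyl group on that sulfur would show, or only with the full tert-butyl. Also open, on these data alone, is how an unbranched butyl chain or a cyclopropyl ring would fare on the same sulfur.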